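Moving the trifluoromethyl around the benzyl ether

The source may hold more compounds than are shown below. What is called first, only, known or untested is meant among the compounds shown, and "the series" means these compounds.

Compound 3 `CN(c1ccc(NC(=O)c2cc(C(F)(F)F)cc(C(F)(F)F)c2)cc1OCc1ccc(C(F)(F)F)cc1)S(=O)(=O)Cc1ccccc1` gives 293000 nM in an ADME assay on HEK293 cells (Homo sapiens) for cytotoxicity, read by MTT assay, with a stated time of 48 h (on this read-out higher numbers stand for weaker inhibition and lower numbers for stronger inhibition), the higher of the two values that were reported as numbers. Compound 2 `CN(c1ccc(NC(=O)c2cc(C(F)(F)F)cc(C(F)(F)F)c2)cc1OCc1cccc(C(F)(F)F)c1)S(=O)(=O)Cc1ccccc1`, which carries 3-(trifluoromethyl)phenyl rather than 4-(trifluoromethyl)phenyl on a saturated chain carbon bound to an oxygen on an aromatic ring, gives 59800 nM. For the measured compounds named here, the step of a 4.9-fold higher number from compound 2 to compound 3 (0.69 log units; beyond the scatter) is the only measured step that bears on the change considered here. Compound 1 `CN(c1ccc(NC(=O)c2cc(C(F)(F)F)cc(C(F)(F)F)c2)cc1OCc1ccccc1C(F)(F)F)S(C)(=O)=O` gives > 500000 nM, which is a limit of this assay rather than a number (the limit of > 500000 nM in this assay, at which 1 of the 3 values shown sits). Compound 4 `CN(c1ccc(NC(=O)c2cc(C(F)(F)F)cc(C(F)(F)F)c2)cc1OCc1ccccc1C(F)(F)F)S(=O)(=O)Cc1ccccc1`, not yet measured, differs from compound 3 by 2-(trifluoromethyl)phenyl in place of 4-(trifluoromethyl)phenyl on a saturated chain carbon bound to an oxygen on an aromatic ring. Going by the values given here, compound 1 shares this 2-(trifluoromethyl)phenyl with compound 4 but differs from it elsewhere as well, so no single step links the two. The one measured move of the trifluoromethyl was modest, and compound 3 already sits close to the limit, so a step of a 1.1-fold higher number from compound 3 to compound 4 (0.05 log units; within the scatter) toward weaker inhibition is expected, with a real chance that only a limit is reported. Compound 4 is therefore estimated at 330000 nM, between 110000 nM and 1000000 nM.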

Compound 4, half-maximal inhibitory concentration: > 500000 nM
Compound 4: no number, only a limit; the forecaster's own chance of this, stated with the estimate: 40%; middle value at least 1.5-fold (0.18 log units) away from the limit.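

In this assay compound 4 gives a limit and not a number: the limit of > 500000 nM in this assay, at which 2 of the 4 values shown sit.

With the benzyl sulfonyl group held constant, 2-(trifluoromethyl)phenyl now shows the largest readable shift in this series, with an at least 8.3-fold higher number from compound 2 to compound 4 (0.92 log units; beyond the scatter), while an at least 1.7-fold higher number from compound 3 to compound 4 (0.23 log units; that floor lies within the scatter) leaves open whether the 2- and 4-substituted compounds truly differ. The step from compound 1 to compound 4 cannot be read, as both are limits.

On these data alone, how far compound 4 lies past its limit remains open, and with it the true size of both readable steps. Also open, as far as these compounds go, is whether a chlorine or a methoxy group in place of trifluoromethyl would show the same dependence on position on this ring.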